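The source may hold more compounds than are shown below. What is called first, only, known or untested is meant among the compounds shown, and "the series" means these compounds.

Measured so far in an ADME assay on 184B5 cells (Homo sapiens) for cytotoxicity, read by MTT assay, with a stated time of 72 h; on this read-out higher numbers stand for weaker inhibition of growth and lower numbers for stronger inhibition of growth:

compound 1 `CC(C)COC(=O)Nc1ccc([Se]C#N)cc1`: 5800 nM
compound 2 `N#C[Se]c1ccc(NC(=O)Oc2ccccc2)cc1`: 400 nM

Compound 1 gives the highest of the two numbers in this assay; its nearest neighbour is compound 2, which differs from it in one place. Within the data shown here, the one measured step on the carbamate oxygen, phenyl in place of isobutyl, gave a 15-fold lower number from compound 1 to compound 2 (1.16 log units; beyond the scatter) in this assay.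

Compound 3 `N#C[Se]c1ccc(NC(=O)OCc2ccccc2)cc1` is not yet measured. It differs from compound 1 by phenyl in place of isopropyl on a saturated chain carbon bound to an oxygen next to a carbonyl group. This change is related to, but not the same as, the step from compound 1 to compound 2: here the phenyl enters on a saturated chain carbon that remains bound to the oxygen, so one carbon of the chain stays in place. Among the measured compounds shown here, the only step that bears on it, from compound 1 to compound 2, was large and beyond the scatter, so a lower number in this assay is expected for compound 3, likely a step smaller than that seen for compound 2 but beyond the scatter. The expected step is a 3.9-fold lower number from compound 1 to compound 3 (0.59 log units; beyond the scatter). For compound 3 the estimate in this assay is 1500 nM, with a range from 500 nM to 5000 nM.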

Compound 3, concentration for 50% growth inhibition: 5000 nM
Estimate against measurement, compound 3: 3.3-fold (0.52 log units) below; the range from low to high includes it.
By their numbers in this assay, from the lowest: compound 2; then compounds 3 and 1 (each within the scatter of the next).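

Working from this assay, phenyl in place of isopropyl on a saturated chain carbon bound to an oxygen next to a carbonyl group gave a 1.2-fold lower number from compound 1 to compound 3 (0.06 log units; within the scatter), whereas phenyl in place of isobutyl on that oxygen gave a 15-fold lower number from compound 1 to compound 2 (1.16 log units; beyond the scatter). A phenyl group in the side chain is therefore not enough on its own to give a low number: with phenyl on the saturated chain carbon, compound 3 stays within the scatter of compound 1, and the low number in this short series rests on compound 2 alone, at 400 nM. Nothing measured here accounts for the different outcomes of the two placements of the phenyl.

Still open, from the compounds shown here alone, is whether a longer chain ending in phenyl also stays within the scatter of compound 1, and whether a chlorine or a methoxy group on the phenyl of compound 2 moves the number in either direction. A side chain carrying an amine or a carboxylic acid is also untested among the compounds shown, so the tolerance of this position beyond hydrocarbon groups remains unknown.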